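Aryl fluoro removed: from compound 1 to compound 4

The source may report more compounds than this note shows. Statements on the series, on what has been measured and on what is new or still open speak of the compounds shown alone.

The series shares one core with a para-substituted phenyl group. Compound 1 `OC[C@@]1(c2ccc(F)cc2)NC[C@@H](O)[C@@H]1O` gives 6.6% in an assay on isolated protein for inhibition of alpha-mannosidase (Canavalia ensiformis), tested at 1000 uM; a higher number here means more inhibition at the concentration tested (going by the name of the read-out), a lower number less inhibition. Its mirror image, compound 2 `OC[C@]1(c2ccc(F)cc2)NC[C@H](O)[C@H]1O`, gives 6.6% in this assay, so the step of no change at the digits printed from compound 1 to compound 2 (within the scatter) is flat; the two differ only in configuration, (the fact that compounds 1 and 2 differ only in the configuration as drawn). Compound 3 `COc1cccc([C@@]2(CO)NC[C@H](O)[C@H]2O)c1`, carrying a methoxy group on the aryl ring, gives 0% in this assay. Compound 1 thus stands level with compound 2 at the top of three numbers, and compound 3 sits a little lower, within the scatter. All three numbers lie near the floor of the read-out.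

Compound 4 `OC[C@@]1(c2ccccc2)NC[C@@H](O)[C@@H]1O` differs from compound 1 by hydrogen in place of fluoro on an aromatic carbon. Within the data shown here, no measured step covers a fluoro-to-hydrogen exchange; the only measured step, a full inversion of configuration, shows no change, and compound 3 with a different aryl substitution pattern shows a number within the scatter of compound 1. Nothing in the data suggests that the aryl substituent moves the read-out beyond its scatter. Compound 4 is therefore expected to give 5%, ranging from 0% to 15%. The step of a number 1.6 percentage points lower from compound 1 to compound 4 (within the scatter) is expected to stay within the scatter.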

Compound 4, a percentage reported as inhibition, at one concentration (the size of the read-out at that concentration, not a potency): 0%
Beside the measured number, compound 4's estimate is 5 percentage points above it, within the range that was stated.
By their numbers in this assay, from the lowest: compounds 3, 4, 1 and 2 (each within the scatter of the next).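

Among these compounds, replacing fluoro with hydrogen on the aromatic carbon para to a group of 9 heavy atoms gives the first direct reading at this position in this assay: the exchange gives a number 6.6 percentage points lower from compound 1 to compound 4 (within the scatter). In this pair, fluoro and hydrogen at this position cannot be told apart at the concentration tested, and with both compounds near the floor of the read-out, the pair offers no sign that this position controls inhibition of the enzyme. Nothing on record bears on this particular exchange, so the result stands without an explanation.

Open, going by these compounds, is whether any group at this position can lift the read-out clear of the scatter, for instance a carboxylic acid, an aminomethyl group or a longer alkyl chain, since fluoro and hydrogen alone span only a small change in the substituent and leave the numbers near the floor. Also open is whether the same exchange of fluoro for hydrogen reads the same way on the mirror-image core of compound 2, where the hydrogen counterpart does not appear among the compounds shown.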